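Swapping the Amide Side Chain for a Fluorinated Chain

The source may report more compounds than this note shows. Statements on the series, on what has been measured and on what is new or still open speak of the compounds shown alone.

Compound 1 `CCOC(=O)C[C@H]1CN(C)CC[C@@H]1c1ccc(Cl)cc1`: 101 nM
Compound 2 `CN1CC[C@H](c2ccc(Cl)cc2)[C@@H](CC(=O)N(C)C)C1`: 46 nM

Both values come from an assay on Cortex with Norepinephrine transporter (Rattus norvegicus) as the target; on this read-out lower numbers stand for stronger inhibition and higher numbers for weaker inhibition. Compound 2 holds the lower of the two numbers; the step of a 2.2-fold lower number from compound 1 to compound 2 (0.34 log units; beyond the scatter) is modest but beyond the scatter. Compound 3 `CN1CC[C@H](c2ccc(Cl)cc2)[C@@H](CCCF)C1` has not yet been measured. It differs from compound 2 in one place: 2-fluoroethyl in place of dimethylcarbamoyl on a saturated chain carbon bound to a saturated ring carbon. Within the data shown here, the single measured step, a 2.2-fold lower number from compound 1 to compound 2 (0.34 log units; beyond the scatter), compares two carbonyl-bearing groups and offers no direct guide to removing the carbonyl altogether; no measured compound carries a group without a hydrogen-bond acceptor at this position. Among the measured compounds shown here, since the one change made so far at this side chain moved the number only modestly, compound 3 is expected to stay near compound 2, with wide uncertainty. For compound 3 the expected step is a 1.2-fold lower number from compound 2 to compound 3 (0.06 log units; within the scatter). In this assay compound 3 is estimated at 40 nM, between 10 nM and 160 nM.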

Compound 3, inhibition constant: 356 nM
Beside the measured number, compound 3's estimate is 8.9-fold (0.95 log units) below it; the measured number lies above the stated range.
By their numbers in this assay, from the lowest: compound 2; then compound 1; then compound 3.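

At this side chain the earlier pair only exchanged one carbonyl-bearing group for another, whereas 2-fluoroethyl carries no carbonyl, and in this assay this change gives a 7.7-fold higher number from compound 2 to compound 3 (0.89 log units; beyond the scatter) and a 3.5-fold higher number from compound 1 to compound 3 (0.55 log units; beyond the scatter) as well. The position is therefore less forgiving than the first step alone suggested: among these three compounds, both carbonyl-bearing side chains hold lower numbers than the fluorinated chain of compound 3. No available evidence explains this rise. The three compounds cannot separate the loss of the carbonyl from the arrival of fluorine or the change in group size. A plain propyl chain would test the fluorine on its own, while a primary amide would show whether the two methyl groups of compound 2 matter.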